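From iodo to difluoromethoxy on a sulfonamide nitrogen's ring

This account rests on a few compounds, and the source may have more. Where it says the series, first, only, none or still open, it means among the compounds named here.

Compound 1 `O=C1NCCN1c1ccc(S(=O)(=O)Nc2ccc(I)cc2)cc1` gives 650 nM
Compound 2 `O=C1NCCN1c1ccc(S(=O)(=O)Nc2cccc(Br)c2)cc1` gives 77 nM
Compound 3 `Cc1cc(C)cc(NS(=O)(=O)c2ccc(N3CCNC3=O)cc2)c1` gives 82 nM

These numbers come from a functional assay on HT-29 cells (Homo sapiens) for antiproliferative activity, read by sulforhodamine B assay, with a stated time of 48 h (on this read-out lower numbers stand for stronger inhibition and higher numbers for weaker inhibition), and compound 1 has the highest of the three. Compound 4 `O=C1NCCN1c1ccc(S(=O)(=O)Nc2ccc(OC(F)F)cc2)cc1` has not been measured yet. It keeps the core of compound 1 and changes a single group: difluoromethoxy in place of iodo on an aromatic carbon. In words, difluoromethoxy takes the place of iodo on an aromatic carbon, para to a large group.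

Two measured steps also start from compound 1 and lose its 4-iodophenyl group: an 8.4-fold lower number from compound 1 to compound 2 (0.93 log units; beyond the scatter) and a 7.9-fold lower number from compound 1 to compound 3 (0.90 log units; beyond the scatter). Both are modest and beyond the scatter. Compounds 2 and 3 themselves barely differ, with a 1.1-fold higher number from compound 2 to compound 3 (0.03 log units; within the scatter), which lies within the scatter. For the measured compounds named here, neither step places a new group where the iodo sat, however, so they offer only indirect guidance, and no measured compound tests that exact swap. A lower number is therefore expected in this assay, but probably a smaller drop than those two steps showed. The expected change is a 2.2-fold lower number from compound 1 to compound 4 (0.34 log units; beyond the scatter). For compound 4 the estimated value is 300 nM, with an expected range of 90 nM to 1000 nM.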

Compound 4, half-maximal inhibitory concentration: 650 nM
Compound 4: middle estimate off by 2.2-fold (0.34 log units), on the low side; measured number inside the range.
By their numbers in this assay, from the lowest: compounds 2 and 3 (each within the scatter of the next); then compounds 1 and 4 (each within the scatter of the next).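

In this assay, replacing iodo with difluoromethoxy on an aromatic carbon, para to a large group, gives no change at the digits printed from compound 1 to compound 4 (within the scatter). For the compounds shown here, this is the first direct test of this position, and it shows that a single iodine atom can give way to a group of four heavy atoms, one of them a hydrogen-bond acceptor, without a change beyond the scatter. The earlier steps from compound 1 removed the 4-iodophenyl group as a whole, so they could not separate the identity of the group at this position from the other differences in the ring; the present pair holds the position fixed and changes only the group, and no information shown explains why the two groups match here.

From the compounds shown here alone, whether an amine or a carboxylic acid at this same position would also leave the number unchanged remains open. It is also unknown whether difluoromethoxy would behave differently on the ring carbon where compound 2 carries its bromo, since only one placement of this group is shown.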